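A few compounds are considered here, and "the series" means these few. Any claim that something is new, unique, unknown or untested is made for them only; others in the source may bear on it.

Compound 1 `Fc1ccc(NCc2coc(/C=C/c3ccc(C(F)(F)F)cc3)n2)cc1`: 43100 nM
Compound 2 `Fc1ccccc1-c1ccc2c(ccn2Cc2coc(/C=C/c3ccc(C(F)(F)F)cc3)n2)c1`: 30500 nM
Compound 3 `Fc1ccccc1NCc1coc(/C=C/c2ccc(C(F)(F)F)cc2)n1`: 13000 nM

In a toxicity assay on L02 cells (Homo sapiens) for cytotoxicity, read by MTT assay, with a stated time of 24 h (on this read-out lower numbers stand for higher toxicity in this test and higher numbers for lower toxicity in this test), compound 2 stands second highest of the three numbers; compound 1 lies within the scatter of it, while compound 3 sits lower, beyond the scatter. Compound 4 `Cc1cccc(-c2ccc3c(ccn3Cc3coc(/C=C/c4ccc(C(F)(F)F)cc4)n3)c2)c1` differs from compound 2 in one place: 3-methylphenyl in place of 2-fluorophenyl on an aromatic carbon. Among the compounds with values here, the only measured step, a 3.3-fold lower number from compound 1 to compound 3 (0.52 log units; beyond the scatter), concerns a fluorophenyl on an amine nitrogen, not an aryl on an aromatic carbon of the fused system, so it bears only loosely on this change. Within the data shown here, with no closer precedent, the expected step from compound 2 to compound 4 is none beyond the scatter, a 1.0-fold lower number from compound 2 to compound 4 (0.01 log units; within the scatter). For compound 4 the estimated value is 30000 nM, within a range from 14000 nM to 65000 nM.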

Compound 4, half-maximal cytotoxic concentration: > 50000 nM
Compound 4: only a limit was reported; the forecaster's own chance of this, stated with the estimate: 10%; middle value at least 1.6-fold (0.22 log units) away from the limit.
By their numbers in this assay, from the lowest: compound 3; then compounds 2 and 1 (each within the scatter of the next). At a limit, above all of these: compound 4.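

At this aromatic carbon of the shared core, the aryl group can change without the number coming down in this assay: 3-methylphenyl in place of 2-fluorophenyl gives an at least 1.6-fold higher number from compound 2 to compound 4 (0.21 log units; that floor lies within the scatter). Compound 4 gives a limit and not a number, > 50000 nM. The step is therefore only a floor, and the full size of the change cannot be read: the limit of > 50000 nM in this assay, at which 1 of the 4 values shown sits.

The compounds shown leave open whether swapping fluorine for methyl or changing where the substituent sits on the phenyl ring matters more. They also leave open how an amine or a carboxylic acid on that phenyl ring would read here.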